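This account rests on a few compounds, and the source may have more. Where it says the series, first, only, none or still open, it means among the compounds named here.

In an ADME assay on HEK-293T cells (Homo sapiens) for inhibition, read by CCK-8 assay, with a stated time of 48 h, tested at 20 uM (on this read-out lower numbers stand for less inhibition of growth and higher numbers for more inhibition of growth at the one concentration tested), three related compounds have been measured so far. Compound 3 (`Cc1ccc(Cc2nnc(NC(=O)/C(C#N)=C/c3ccccc3OS(=O)(=O)c3ccc(C)cc3)s2)cc1`) gives 22% and lies within the scatter of compound 1 (`N#C/C(=C\c1ccccc1OS(=O)(=O)c1ccc(Cl)cc1)C(=O)Nc1nnc(Cc2ccccc2)s1`), which gives 25% in the same test. Compound 2 (`N#C/C(=C\c1ccccc1OS(=O)(=O)c1ccc(Cl)cc1)C(=O)Nc1nnc(Cc2ccc(F)cc2)s1`) gives 6% in this test. That number stands lower than the other two, beyond the scatter.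

Compound 4 (`Cc1ccc(Cc2nnc(NC(=O)/C(C#N)=C/c3ccccc3OS(=O)(=O)c3ccc(Cl)cc3)s2)cc1`) differs from compound 3 in one place: chloro in place of methyl on an aromatic carbon, para to a large group, so that (4-methylphenyl)sulfonyl becomes (4-chlorophenyl)sulfonyl (chloro in place of methyl on an aromatic carbon). Going by the values given here, no measured step covers this exchange. Among the compounds with values here, the only single change with numbers is a number 19 percentage points lower from compound 1 to compound 2 (beyond the scatter) for fluoro in place of hydrogen on an aromatic carbon. That is a different exchange, and it shows only that one small substitution can move the number beyond the scatter. Closer guidance comes from the (4-chlorophenyl)sulfonyl group that compound 4 shares with compound 1, which gives 25% in this test, within the scatter of compound 3.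

A shift beyond the scatter in this assay is therefore not expected. The estimate amounts to a number 2 percentage points lower from compound 3 to compound 4 (within the scatter) as the expected step. For compound 4 the estimated value is 20% with an expected range of 6% to 36% in this test.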

Compound 4, percent growth inhibition at one concentration: 8%
Estimate against measurement, compound 4: 12 percentage points above; low and high end bracket the measured number.
By their numbers in this assay, from the lowest: compounds 2 and 4 (each within the scatter of the next); then compounds 3 and 1 (each within the scatter of the next).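

In this assay the sulfonyl side now has a measured step of its own: chloro in place of methyl on an aromatic carbon, para to a large group, gives a number 14 percentage points lower from compound 3 to compound 4 (beyond the scatter), so a change at this place alone can move the number beyond the scatter. With the (4-chlorophenyl)sulfonyl group held fixed, methyl in place of hydrogen on the aromatic carbon that bears fluoro in compound 2 gives a number 17 percentage points lower from compound 1 to compound 4 (beyond the scatter), in the same direction as the earlier a number 19 percentage points lower from compound 1 to compound 2 (beyond the scatter), while methyl in place of fluoro gives a number 2 percentage points higher from compound 2 to compound 4 (within the scatter), so this test does not tell those two substituents apart at that carbon. The data shown offer no measurement that explains either shift.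

Going by these compounds, what a methoxy group or an amine would do on the aromatic carbon of the sulfonyl side remains open, and so does hydrogen at that place. It is also open whether the step from methyl to chloro would keep its size with fluoro or hydrogen in place of the methyl at the other end of these compounds.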